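The source may report more compounds than this note shows. Statements on the series, on what has been measured and on what is new or still open speak of the compounds shown alone.

Measured so far, in a functional assay on HCT-116 cells (Homo sapiens) for antiproliferative activity, read by CCK-8 assay, with a stated time of 72 h, tested at 8 uM; on this read-out higher numbers stand for a stronger effect at the one concentration tested and lower numbers for a weaker effect:

compound 1, `COC(CCn1cnc2c(NCc3ccc(C(=O)Nc4ccccc4N)cc3)nc(Cl)nc21)OC`, gives 11.9%
compound 2, `CC(C)n1cnc2c(Nc3ccccc3)nc(NCOCc3ccc(C(=O)Nc4ccccc4N)cc3)nc21`, gives 18.8%
compound 3, `Nc1ccccc1NC(=O)c1ccc(COCNc2nc(Nc3ccc(-c4ccccc4)cc3)c3ncn(C4CCCC4)c3n2)cc1`, gives 25.8%

Compound 3 stands at the top of these three numbers. Its nearest neighbour is compound 2, whose value lies within the usual scatter of this assay, so the two cannot be told apart on this evidence. Compound 1 lies further down, beyond the scatter, so compound 3 is clearly stronger than compound 1 at the single concentration tested.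

The next compound, compound 4, `Nc1ccccc1NC(=O)c1ccc(COCNc2nc(Nc3ccccc3)c3ncn(C4CCCC4)c3n2)cc1`, has not yet been measured. It differs from compound 3 in one place:

hydrogen in place of phenyl on an aromatic carbon

Going by the values given here, no pair of measured compounds differs in exactly one place, so no measured step can be set beside this change. What can be said is that compound 2, which also carries a plain phenyl at the same position as compound 4 does, gives a number that sits within the scatter of compound 3. On that basis the step from compound 3 to compound 4 is expected to be small, a slight fall that stays within the scatter, a number 7.8 percentage points lower from compound 3 to compound 4 (within the scatter). Compound 4 is therefore estimated at 18%, with a range from 8% to 28%.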

Compound 4, a percentage reported as inhibition, at one concentration (the size of the read-out at that concentration, not a potency): 76.9%
The estimate for compound 4 lay 58.9 percentage points below the measured number, outside the stated range (above it).
By their numbers in this assay, from the lowest: compounds 1, 2 and 3 (each within the scatter of the next, the first and the last beyond it); then compound 4.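

In this assay, cutting 4-phenylphenyl back to phenyl gives a number 51.1 percentage points higher from compound 3 to compound 4 (beyond the scatter), so this aromatic carbon, para to a large group, is a place where the outer ring counts heavily against the read-out. The group on the aromatic nitrogen also matters, since cyclopentyl in place of isopropyl gives a number 58.1 percentage points higher from compound 2 to compound 4 (beyond the scatter) once phenyl is held fixed. Compound 4 carries both phenyl and cyclopentyl, while compound 3 has only the cyclopentyl and compound 2 only the phenyl, and each of these two changes on its own separates a weak number from a strong one.

Nothing available explains why either change has so large an effect. Still open, from the compounds shown here alone, is how this carbon responds to a small group such as methyl, methoxy or an amine in place of the hydrogen, and how the aromatic nitrogen responds to cyclohexyl or a longer chain; these numbers also come from one concentration, so they do not give potency.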